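Sulfur substituent trimmed from benzyl to isopropyl

The source may hold more compounds than are shown below. What is called first, only, known or untested is meant among the compounds shown, and "the series" means these compounds.

In an assay on isolated protein for binding affinity to Equilibrative nucleoside transporter 1 (Homo sapiens) (a higher number here means a weaker inhibitor, a lower number a stronger inhibitor), compound 1 `O=[N+]([O-])c1ccc2c(c1)CN(c1ncnc3c1ncn3[C@@H]1O[C@H](CO)[C@@H](O)[C@H]1O)CC2` gives 5.5 nM. Compound 2 `Nc1nc(SCc2cccc(Br)c2)c2ncn([C@@H]3O[C@H](CO)[C@@H](O)[C@H]3O)c2n1` gives 2880 nM in this assay, the higher of the two numbers; the gap to compound 1 lies beyond the scatter. Compound 3 `CC(C)Sc1nc(N)nc2c1ncn2[C@@H]1O[C@H](CO)[C@@H](O)[C@H]1O` is not yet measured. It differs from compound 2 by isopropyl in place of 3-bromobenzyl on a sulfur. Among the compounds with values here, no measured pair shows this change, so the expected step from compound 2 to compound 3 is a loosening of a 3.5-fold higher number from compound 2 to compound 3 (0.54 log units; beyond the scatter) in this assay, of a size beyond the scatter. Compound 3 is estimated at 10000 nM, ranging from 3000 nM to 40000 nM.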

Compound 3, half-maximal inhibitory concentration: 191000 nM
Compound 3: the middle estimate sits 19-fold (1.28 log units) below what was measured; measured number outside the range, above it.
By their numbers in this assay, from the lowest: compound 1; then compound 2; then compound 3.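

Within the data shown here, the first single-place comparison puts isopropyl in place of 3-bromobenzyl on a sulfur and gives a 66-fold higher number from compound 2 to compound 3 (1.82 log units; beyond the scatter) in this assay. The group on this sulfur therefore has a large influence on the number, and the 3-bromobenzyl compound reads lower. Nothing available accounts for the size of this step.

Still open, from the compounds shown here alone, is whether the step follows the aromatic ring or the bromine, which a plain benzyl on the same sulfur would separate. Also open, going by these compounds, is how a longer chain ending in an amine or carboxylic acid would read here.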